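Working notes: one added methyl on the amide-side chain

A few compounds are considered here, and "the series" means these few. Any claim that something is new, unique, unknown or untested is made for them only; others in the source may bear on it.

Measured so far:
- compound 1 `Cc1nc(C(=O)c2ccc(C)s2)c2sccc2n1`; in a functional assay on CHO-K1 cells for antagonist activity at adenosine receptor A2b (Homo sapiens), read by FLIPR and calcium flux (a higher number here means a weaker inhibitor, a lower number a stronger inhibitor), compound 1 gives > 10000 nM, which is a limit of the assay and not a number.
- compound 2 `CCc1nc(C(=O)c2ccc(C)s2)c2sccc2n1`; in this assay compound 2 gives 3670 nM.
- compound 3 `CCNC(=O)c1nc(NCc2cccnc2)nc2ccsc12`; in this assay compound 3 gives 120 nM.

Among the measured compounds shown here, the only single-point step measured is methyl in place of hydrogen on a saturated chain carbon bound to an aromatic carbon, which gives an at least 2.7-fold lower number from compound 1 to compound 2 (0.43 log units; beyond the scatter). Its size is bounded on one side because compound 1 sits at the limit of > 10000 nM in this assay, at which 1 of the 3 values shown sits. Compound 3 holds the lowest number of the two that are numbers; against compound 2 its value stands far lower, beyond the scatter. The difference between the core of compound 3 and the core of compound 1 is not broken down here.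

Compound 4 `CC(C)NC(=O)c1nc(NCc2cccnc2)nc2ccsc12` is not yet measured. Its change from compound 3 is methyl in place of hydrogen on a saturated chain carbon bound to an amide-type nitrogen and a saturated chain carbon. This is the same kind of change as from compound 1 to compound 2, but not the same: there the place is a saturated chain carbon bound to an aromatic carbon, here it is a saturated chain carbon bound to an amide-type nitrogen and a saturated chain carbon.

For compound 4 a step of a 1.3-fold lower number from compound 3 to compound 4 (0.12 log units; within the scatter) is expected, set beside an at least 2.7-fold lower number from compound 1 to compound 2 (0.43 log units; beyond the scatter); it rests on that single step, whose size is only a bound because compound 1 sits at the limit of > 10000 nM in this assay, at which 1 of the 3 values shown sits, and on the different place, so the expectation is kept modest. Compound 4 is estimated at 90 nM, between 35 nM and 250 nM.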

Compound 4, half-maximal inhibitory concentration: 309 nM
For compound 4 the middle estimate is 3.4-fold (0.54 log units) below the measured one, and the stated range ends below it.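

In this assay, methyl in place of hydrogen on a saturated chain carbon bound to an amide-type nitrogen and a saturated chain carbon gives a 2.6-fold higher number from compound 3 to compound 4 (0.41 log units; beyond the scatter), so the earlier gain does not carry over to this core and place, and the two steps run in opposite directions: the same change on two cores in this assay, an at least 2.7-fold lower number (0.43 log units; beyond the scatter) from compound 1 to compound 2 and a 2.6-fold higher number (0.41 log units; beyond the scatter) from compound 3 to compound 4, at least 7.0-fold (0.84 log units) apart, beyond the scatter of two such steps The earlier step is only a one-sided bound, and compound 1 stands at a limit of the assay, not at a number: the limit of > 10000 nM in this assay, at which 1 of the 4 values shown sits. The two steps differ in both core and place at once, so this pair does not show which of the two sets the direction, and two steps give no rule for the series as a whole.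

Going by these compounds, it remains open whether isopropyl in place of ethyl on the core of compound 2 would follow compound 4 or compound 2. On these data alone, it also remains open how a longer chain such as propyl, or a cyclopropyl group, would read on the ethylcarbamoyl position of compound 3.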